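Notes on a methoxy step in the series

The compounds below may be only part of what the source reports. "The series", "measured", "known", "first", "only" and "open" are said of these compounds alone.

Measured so far:
- compound 1 `COc1ccc(-c2cc(C(=O)/C=C/c3ccccc3)nc3cc(-c4ccccc4)nn23)cc1OC`: in a functional assay on MDA-MB-231 cells (Homo sapiens) for antiproliferative activity, read by MTT assay, with a stated time of 24 h (on this read-out lower numbers stand for stronger inhibition and higher numbers for weaker inhibition), compound 1 gives 23300 nM
- compound 2 `COc1cc(C(=O)/C=C/c2cc(-c3cc(OC)c(OC)c(OC)c3)n3nc(-c4ccccc4)cc3n2)cc(OC)c1OC`: in this assay compound 2 gives 24300 nM

Compound 1 holds the lower of the two numbers, but its gap to compound 2 lies within the usual scatter, so the two compounds cannot be ordered. Within the data shown here, no pair of measured compounds differs in only one place, so no single-point step is available to lean on.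

Compound 3 `COc1ccc(/C=C/C(=O)c2cc(-c3ccc(OC)c(OC)c3)n3nc(-c4ccccc4)cc3n2)cc1` is the next structure to be measured. Relative to compound 1 the change is methoxy in place of hydrogen on an aromatic carbon. The two measured compounds, which differ in several places at once, give near-identical numbers, so nothing here argues for a large move in either direction. The step from compound 1 to compound 3 is expected to be small, a 1.2-fold lower number from compound 1 to compound 3 (0.07 log units; within the scatter), with no clear direction beyond the scatter. Compound 3 is estimated at 20000 nM, with a range from 8000 nM to 50000 nM.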

Compound 3, half-maximal inhibitory concentration: 22000 nM
Estimate against measurement, compound 3: 1.1-fold (0.04 log units) below, and the stated range covers the measured number.
By their numbers in this assay, from the lowest: compounds 3, 1 and 2 (each within the scatter of the next).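

Among these compounds, this is the first comparison that isolates a single change. In this assay methoxy in place of hydrogen on an aromatic carbon, para to a large group, turning the 2-phenylethenyl into 2-(4-methoxyphenyl)ethenyl, gives a 1.1-fold lower number from compound 1 to compound 3 (0.02 log units; within the scatter) and so leaves compound 1 and compound 3 unordered. At this position, then, this one methoxy step produces no readable move on its own, and no measurement shown speaks to the reason for that.

The compounds shown leave open how an amine, a carboxylic acid or a longer alkoxy chain at that carbon would read. Also open, from the compounds shown here alone, is how much each separate difference between compound 1 and compound 2 contributes, since several changes there remain unseparated by any single-place step.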